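A few compounds are considered here, and "the series" means these few. Any claim that something is new, unique, unknown or untested is made for them only; others in the source may bear on it.

Working notes on the series.

Compound 2 `CCC(C)(CC)Cc1cnc(CCc2ccc(-c3ccccc3C(=O)O)cc2)[nH]1` gives 30 nM in an in vitro functional assay on cells for agonist activity at Bombesin receptor subtype-3 (Mus musculus), read by luminescence and calcium flux (a lower number here means that less compound is needed, a higher number that more compound is needed for the effect), the lowest of the two numbers in hand. For the measured compounds named here, its nearest neighbour is compound 1 `O=C(O)c1ccccc1-c1ccc(CCc2ncc(CCc3ccccc3)[nH]2)cc1`, which in this assay gives 174 nM; the two differ only in the group on the saturated chain carbon bound to an aromatic carbon, and the step of a 5.8-fold lower number from compound 1 to compound 2 (0.76 log units; beyond the scatter) is the one measured change that bears on what follows.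

Compound 3 `Cc1ccc(Cc2cnc(CCc3ccc(-c4ccccc4C(=O)O)cc3)[nH]2)cc1` is not yet measured. It differs from compound 2 by 4-methylphenyl in place of 1-ethyl-1-methylpropyl on a saturated chain carbon bound to an aromatic carbon, so that the same difference, cut one bond further out, reads 2-ethyl-2-methylbutyl to 4-methylbenzyl. This brings the group back close to the benzyl of compound 1, with one added methyl on the ring. Going by the values given here, the only guide is the step from compound 1 to compound 2, which was modest but beyond the scatter; the change to compound 3 undoes most of it, and no measured compound shows what the ring methyl does on its own.

The estimate for compound 3 in this assay is therefore 110 nM, within 35 nM to 350 nM, which corresponds to an expected step of a 3.7-fold higher number from compound 2 to compound 3 (0.56 log units; beyond the scatter).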

Compound 3, half-maximal effective concentration: 162 nM
For compound 3 the middle estimate is 1.5-fold (0.17 log units) below the measured one; the measured number falls inside the stated range.
By their numbers in this assay, from the lowest: compound 2; then compounds 3 and 1 (each within the scatter of the next).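

In this assay, replacing the 1-ethyl-1-methylpropyl group with 4-methylphenyl on the saturated chain carbon bound to an aromatic carbon raises the number by a step beyond the scatter (a 5.4-fold higher number from compound 2 to compound 3 (0.73 log units; beyond the scatter)). The change from benzyl to 4-methylphenyl at the same place stays within the scatter (a 1.1-fold lower number from compound 1 to compound 3 (0.03 log units; within the scatter)), so the two groups that carry an aromatic ring cannot be told apart in this assay. Among the three compounds, the lower number therefore belongs only to compound 2, whose group has no ring, and no compound goes against this so far. No evidence on hand explains the differences at this position.

The compounds shown leave open whether the lower number of compound 2 goes with the loss of the aromatic ring or with the branching of its chain, and a cyclohexyl group or a straight hexyl chain at this place would separate the two readings. They also leave open how this position responds to a group bearing an amine or a methoxy substituent on the ring.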